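Following the Step from Compound 3 to Compound 4

The compounds below may be only part of what the source reports. "The series", "measured", "known", "first", "only" and "open" are said of these compounds alone.

Measured so far:
Compound 1 `c1ccc(-c2ccc(Cn3cncc3CNc3ccc(-c4onc5ccccc45)c(-c4ccccc4)c3)cc2)cc1` gives > 10000 nM in a toxicity assay on NIH3T3 cells (Mus musculus) for cytotoxicity, read by resazurin assay; a higher number here means that more compound is needed for the effect, a lower number that less compound is needed.
Compound 2 `COC(=O)c1ccc(NCc2cncn2Cc2ccc(-c3ccccc3)cc2)cc1-c1ccccc1` gives > 1000 nM in this assay.
Compound 3 `c1ccc(-c2ccc(Cn3cncc3CNc3ccc(N4CCCCC4)c(-c4ccccc4)c3)cc2)cc1` gives > 1000 nM in this assay.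

Every one of these values is a limit of the assay, not a number. Compound 3 stands at the limit of > 1000 nM in this assay, at which 2 of the 3 values shown sit. Compound 1 stands at the limit of > 10000 nM in this assay, at which 1 of the 3 values shown sits.

Compound 4 `c1ccc(-c2ccc(Cn3cncc3CNc3ccc(-c4noc5ccccc45)c(-c4ccccc4)c3)cc2)cc1` differs from compound 3 in this way: a group of 9 heavy atoms (7 carbon, 1 nitrogen, 1 oxygen; one five-membered aromatic ring with 2 hetero atoms, one six-membered aromatic ring of carbon only) in place of a group of 6 heavy atoms (5 carbon, 1 nitrogen; one six-membered non-aromatic ring with 1 hetero atom), on an aromatic carbon. The steps that touch this change are a step that the two limits leave unreadable from compound 2 to compound 3 and a step that the two limits leave unreadable from compound 1 to compound 3, both left unreadable by the limits, so no size can be drawn from them. With all measured values sitting at limits, compound 4 is expected to remain at a limit too, a step that the limit leaves unreadable from compound 3 to compound 4. Compound 4 is therefore estimated at 15000 nM in this assay, with a range from 4000 nM to 60000 nM.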

Compound 4, half-maximal effective concentration: > 10000 nM
Compound 4: a limit, no number; the forecaster's own chance of this, stated with the estimate: 80%; the middle value does not contradict the limit.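

Among the compounds shown here, compound 4, like compounds 1, 2 and 3, gives only a limit, so no step between these compounds can be read. As far as these compounds go, the actual concentration each compound needs in this assay stays open.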